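Removing the drawn configurations from compound 1

The source may report more compounds than this note shows. Statements on the series, on what has been measured and on what is new or still open speak of the compounds shown alone.

Compound 1, whose structure is `C[C@@H](Oc1ccccc1)[C@@H]1CCCN1C`, is the weaker of the two measured compounds in an assay on cell membranes for displacement of a labelled ligand from Neuronal acetylcholine receptor; alpha4/beta2 (Rattus norvegicus), read by scintillation counting (on this read-out lower numbers stand for stronger inhibition and higher numbers for weaker inhibition), where compound 1 gives 1550 nM. Within the data shown here, compound 2, with the structure `CN1CCC[C@H]1COc1cncc(O)c1`, gives 3.7 nM in this assay, a far lower number than compound 1 and well beyond the scatter, though the two structures differ in more than one place and no single step between them is described. Compound 3, drawn as `CC(Oc1ccccc1)C1CCCN1C`, is to be measured in this assay. It differs from compound 1 in this way: the two compounds have the same atoms and bonds; at least one stereo element is drawn with a configuration in one of them and without one in the other: 2 of 2 stereo elements differ; a stereocentre at a saturated chain carbon is drawn R in compound 1 and without a configuration in compound 3; a stereocentre at a saturated ring carbon is drawn S in compound 1 and without a configuration in compound 3. Among the measured compounds shown here, no step between measured compounds is available to calibrate this change. Since the atoms and bonds are unchanged, the step from compound 1 to compound 3 is expected to be small, perhaps a modest rise in the number, so a 1.6-fold higher number from compound 1 to compound 3 (0.21 log units; within the scatter) is estimated. Compound 3 is therefore expected to give about 2500 nM, within roughly 800 nM to 8000 nM.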

Compound 3, inhibition constant: 4590 nM
For compound 3 the middle estimate is 1.8-fold (0.26 log units) below the measured one; the measured number falls inside the stated range.
By their numbers in this assay, from the lowest: compound 2; then compound 1; then compound 3.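

Removing the drawn configurations leaves every atom and bond in place, yet in this assay the change gives a 3.0-fold higher number from compound 1 to compound 3 (0.47 log units; beyond the scatter). So the configuration drawn at the saturated chain carbon and the saturated ring carbon counts for something in this series, with the defined form, compound 1, showing the stronger inhibition; compounds 1 and 2 could not show this, as they differ in more than one place. The only difference behind the step is this: the fact that one of compounds 1 and 3 is drawn with a defined configuration and the other without, at the place where they differ

The compounds shown do not separate the two stereocentres, so how much of the step belongs to each, and how any other single configuration would read, stays open. Also open, from the compounds shown here alone, is what a methoxy group or a fluorine on the core of compound 1 would do in this assay.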